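This account rests on a few compounds, and the source may have more. Where it says the series, first, only, none or still open, it means among the compounds named here.

In an ADME assay on S9 fraction from liver (Mus musculus, strain ICR/CD-1) for metabolic stability, read by LC-MS, using NADPH, with a stated time of 5 min, tested at 2 uM (a higher number here means that the compound lasts longer, a lower number that the compound disappears faster), compound 2 `CC1CCN(C2CCN(S(=O)(=O)c3cccc(-c4ccc(F)cc4)c3)CC2)CC1` gives 1.28 h, the highest of the three numbers shown. Compound 1 `CC1CCN(C2CCN(S(=O)(=O)c3cccc(-c4ccccc4C(F)(F)F)c3)CC2)CC1` gives 0.617 h in this assay, and compound 3 `COc1ccc(OC)c(S(=O)(=O)N2CCC(N3CCC(C)CC3)CC2)c1` gives 0.157 h. Compound 4 `CC1CCN(C2CCN(S(=O)(=O)c3cccc(-c4ccc5ccccc5c4)c3)CC2)CC1` differs from compound 2 in one place: naphthalen-2-yl in place of 4-fluorophenyl on an aromatic carbon. For the measured compounds named here, the only measured step that touches this group is a 2.1-fold higher number from compound 1 to compound 2 (0.32 log units; beyond the scatter), a modest change that came with swapping the group at this place. That step suggests such a swap can move the half-life by a modest amount, but nothing measured shows which way naphthalen-2-yl will go. The step expected is therefore a 1.4-fold lower number from compound 2 to compound 4 (0.15 log units; within the scatter), small against a wide range. Compound 4 is estimated at 0.9 h in this assay, between 0.35 h and 2.3 h.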

Compound 4, half-life: 3.4 h
Beside the measured number, compound 4's estimate is 3.8-fold (0.58 log units) below it; measured number above the stated range.
By their numbers in this assay, from the lowest: compound 3; then compound 1; then compound 2; then compound 4.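

Two steps in this assay now run the same way, a 2.7-fold higher number from compound 2 to compound 4 (0.42 log units; beyond the scatter) and a 5.5-fold higher number from compound 1 to compound 4 (0.74 log units; beyond the scatter) both with naphthalen-2-yl entering on this aromatic carbon. For the compounds shown here, the earlier step compared only two groups with one aromatic ring each, whereas here a group with two such rings gives a longer half-life than either of them. No measured evidence here explains this rise. Going by these compounds, whether it belongs to the second ring or to the loss of fluorine stays open. A plain phenyl or a quinolinyl group at this place would help to separate the two.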